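Hydroxycarbamoyl chain length in the CNE-2 series

A few compounds are considered here, and "the series" means these few. Any claim that something is new, unique, unknown or untested is made for them only; others in the source may bear on it.

In a functional assay on CNE-2 cells (Homo sapiens) for inhibition, read by MTT assay, with a stated time of 72 h (a lower number here means a stronger inhibitor, a higher number a weaker inhibitor), compound 1 `Nc1nc2cc(-c3nn(CCCCCCCCCC(=O)NO)c4ncnc(N)c34)ccc2o1` gives 36800 nM. Compound 2 `Nc1nc2cc(-c3nn(CCC(=O)NO)c4ncnc(N)c34)ccc2o1` stands at > 150000 nM, which is a limit of the assay and not a number. Compound 3 `Nc1nc2cc(-c3nn(CCCCC(=O)NO)c4ncnc(N)c34)ccc2o1` carries 2-(hydroxycarbamoyl)ethyl in place of hydroxycarbamoyl on a saturated chain carbon, two bonds along the chain from an aromatic nitrogen. Among the measured compounds shown here, the one measured step bearing on this is an at least 4.0-fold higher number from compound 1 to compound 2 (0.61 log units; beyond the scatter), and it swaps 7-(hydroxycarbamoyl)heptyl for hydroxycarbamoyl at that place. The new group lies between those two, so a partial reversal toward a lower number in this assay is expected, as an at least 1.7-fold lower number from compound 2 to compound 3 (0.24 log units; that floor lies within the scatter). Compound 3 is estimated at 85000 nM, within 35000 nM to 160000 nM.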

Compound 3, half-maximal inhibitory concentration: > 50000 nM
Compound 3 ended at the assay's limit (the forecaster's own chance of this, stated with the estimate: 30%); the middle value does not contradict the limit.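

In this assay compound 3 stands at > 50000 nM, a limit of the assay and not a number. Among the compounds shown here, the only readable comparison with the longer chain is an at least 1.3-fold higher number from compound 1 to compound 3 (0.13 log units; that floor lies within the scatter), so 2-(hydroxycarbamoyl)ethyl at this place is not yet separated from the chain of compound 1. The step from compound 2 to compound 3 cannot be read, as both values are limits.

On these data alone, how far compound 3 actually lies from compound 1 remains open. Also open, as far as these compounds go, is whether a carboxylic acid in place of the hydroxycarbamoyl end, or a chain longer than that of compound 1, would give a lower number.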